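This account rests on a few compounds, and the source may have more. Where it says the series, first, only, none or still open, it means among the compounds named here.

Measured so far:
- compound 1 `N#Cc1ccccc1C1OCC(C/C=C\CCC(=O)O)C(c2cccnc2)O1` gives 54 nM
- compound 2 `O=C(O)CC/C=C\CC1COC(c2ccc([N+](=O)[O-])cc2)OC1c1cccnc1` gives 39 nM

In an assay for inhibition of Thromboxane-A synthase (Homo sapiens), using microsomes (on this read-out lower numbers stand for stronger inhibition and higher numbers for weaker inhibition), compound 2 stands at the lowest of the two numbers, but the step of a 1.4-fold lower number from compound 1 to compound 2 (0.14 log units; within the scatter) is within the scatter, so the two compounds are not separated. Compound 3 `O=C(O)CC/C=C\CC1COC(c2ccc(C(F)(F)F)cc2)OC1c1cccnc1` differs from compound 2 by trifluoromethyl in place of nitro on an aromatic carbon. Among the measured compounds shown here, the only measured step that bears on this position, a 1.4-fold lower number from compound 1 to compound 2 (0.14 log units; within the scatter), did not leave the scatter, so no step beyond the scatter is expected: a 1.2-fold higher number from compound 2 to compound 3 (0.06 log units; within the scatter). Compound 3 is estimated at 45 nM, with a range from 18 nM to 110 nM.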

Compound 3, half-maximal inhibitory concentration: 44 nM
Estimate against measurement, compound 3: 1.0-fold (0.01 log units) above; measured number inside the range.
By their numbers in this assay, from the lowest: compounds 2, 3 and 1 (each within the scatter of the next).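

Swapping nitro for trifluoromethyl on this aromatic carbon (a 1.1-fold higher number from compound 2 to compound 3 (0.05 log units; within the scatter)) does not separate the two compounds in this assay, so the hydrogen-bond acceptors counted on nitro are not required here for a number in this range. The wider change from 2-cyanophenyl to 4-(trifluoromethyl)phenyl (a 1.2-fold lower number from compound 1 to compound 3 (0.09 log units; within the scatter)) also stays within the scatter, leaving all three aryl groups unseparated. Nothing available explains this flat result.

Still open, from the compounds shown here alone, is whether an amine or a carboxylic acid on this aromatic carbon would stay in the same range. Going by these compounds, the unsubstituted phenyl group also remains open as a reference point for the series.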